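This account rests on a few compounds, and the source may have more. Where it says the series, first, only, none or still open, it means among the compounds named here.

Working notes on the indolyl acrylonitrile series.

The series is compared in a functional assay on MIA PaCa-2 cells (Homo sapiens) for cytotoxicity, read by WST assay, with a stated time of 48 h; a lower number here means a stronger inhibitor, a higher number a weaker inhibitor. Compound 1 `COc1ccc2[nH]cc(/C=C(\C#N)C(=O)c3c[nH]c4ccccc34)c2c1` carries a methoxy on the ring of the aldehyde-derived part and an unsubstituted aroyl part; in this assay compound 1 gives 25100 nM. Compound 2 `COc1ccc2[nH]cc(/C=C(\C#N)C(=O)c3c[nH]c4ccc(OC)cc34)c2c1` adds a second methoxy on the aroyl part, a change counted as methoxy in place of hydrogen on an aromatic carbon. For compound 2 this assay reports only a limit, > 50000 nM. The step is therefore an at least 1.9-fold higher number from compound 1 to compound 2 (0.29 log units; that floor lies within the scatter); its floor is set by the limit of > 50000 nM in this assay, at which 1 of the 3 values shown sits, so its true size is not known.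

Compound 3 `N#C/C(=C\c1c[nH]c2cc(F)ccc12)C(=O)c1c[nH]c2ccccc12` has a fluorine rather than a methoxy on the aldehyde-derived part and an unsubstituted aroyl part; in this assay compound 3 gives 31600 nM, which sits close to compound 1. The difference between the core of compound 3 and the core of compound 1 is not broken down here.

Compound 4 `COc1ccc2c(C(=O)/C(C#N)=C/c3c[nH]c4cc(F)ccc34)c[nH]c2c1` is to be measured. It differs from compound 3 by methoxy in place of hydrogen on an aromatic carbon, the same change that carried compound 1 to compound 2, made at an identically described place. Given that the measured step of an at least 1.9-fold higher number from compound 1 to compound 2 (0.29 log units; that floor lies within the scatter) reached the limit, a step of similar size is expected, a 1.7-fold higher number from compound 3 to compound 4 (0.24 log units; within the scatter). Compound 4 is thus expected to give about 55000 nM, with a range from 28000 nM to 120000 nM, and there is a fair chance the assay returns only a limit.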

Compound 4, half-maximal inhibitory concentration: > 50000 nM
Compound 4: a limit, no number; the forecaster's own chance of this, stated with the estimate: 55%; the middle value does not contradict the limit.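

In this assay compound 4 gives > 50000 nM, which is a limit and not a number. The new step therefore has only a floor, an at least 1.5-fold higher number from compound 3 to compound 4 (0.19 log units; that floor lies within the scatter), and it points the same way as the step on the core of compound 1, so neither core shows the methoxy change yielding a stronger inhibitor, although neither floor clears the usual scatter: the same change on two cores in this assay, an at least 1.9-fold higher number (0.29 log units; that floor lies within the scatter) from compound 1 to compound 2 and an at least 1.5-fold higher number (0.19 log units; that floor lies within the scatter) from compound 3 to compound 4; the limit leaves it open whether they differ. The change can be carried from one core to the other without a reversal in direction being seen, but these data do not show that it has the same size on both cores or that its true size on either core exceeds the scatter: the limit of > 50000 nM in this assay, at which 2 of the 4 values shown sit.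

Going by these compounds, with both methoxy compounds resting on a limit, the true size of the change remains unknown on each core, and only values that fall inside the range of this assay could settle whether the two steps differ. Also open is how an amine, a carboxylic acid or a longer chain such as propoxy would read in place of that aromatic hydrogen on either core, since methoxy is the only group shown entering there.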